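The compounds below may be only part of what the source reports. "The series", "measured", "known", "first", "only" and "open" are said of these compounds alone.

Measured in an assay on cells for inhibition of Amine oxidase [flavin-containing] B (Homo sapiens), read by fluorescence, with stated times of 30 min and 15 min, tested at 1 uM; a higher number here means more inhibition at the concentration tested (going by the name of the read-out), a lower number less inhibition:
Compound 1 `COc1ccc(OCCOc2ccc3[nH]c(=O)n(C(C)C)c3c2)cc1` gives 15.5%
Compound 2 `CCn1c(=O)[nH]c2ccc(OCCOc3ccc(OC)cc3)cc21` gives 13.9%
Compound 3 `Cn1c(=O)[nH]c2ccc(OCCCc3ccccc3)cc21` gives 14%

The three values lie close together. Compound 3 and compound 2 carry different cores; that difference is not broken down here. Compound 4 `CCn1c(=O)[nH]c2ccc(OCCCc3ccccc3)cc21` is not yet measured; it differs from compound 3 by methyl in place of hydrogen on a saturated chain carbon bound to an aromatic nitrogen. The same kind of change separates compound 2 from compound 1: methyl in place of hydrogen on a saturated chain carbon bound to an aromatic nitrogen and a saturated chain carbon. The two places are not identical, since in the pair compound 2 to compound 1 the chain carbon is bound to an aromatic nitrogen and a saturated chain carbon, whereas in compound 3 to compound 4 it is bound to an aromatic nitrogen only. In this assay that earlier change made a number 1.6 percentage points higher from compound 2 to compound 1 (within the scatter). A step of similar size is expected here, a number 1 percentage points higher from compound 3 to compound 4 (within the scatter), because the change from compound 2 to compound 1 gave a number 1.6 percentage points higher from compound 2 to compound 1 (within the scatter). Compound 4 is therefore estimated at 15%, likely between 6% and 24%.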

Compound 4, a percentage reported as inhibition, at one concentration (the size of the read-out at that concentration, not a potency): 4.56%
Compound 4: middle estimate off by 10.4 percentage points, on the high side; measured number below the stated range.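

Putting methyl in place of hydrogen on a saturated chain carbon bound to an aromatic nitrogen gives a number 9.4 percentage points lower from compound 3 to compound 4 (within the scatter) in this assay for this pair. Set beside the same change on the other core, this step does not stand out from what repeated measurements would give: the same change on two cores in this assay, a number 1.6 percentage points higher (within the scatter) from compound 2 to compound 1 and a number 9.4 percentage points lower (within the scatter) from compound 3 to compound 4, 11 percentage points apart, within the scatter of two such steps.
So these two pairs show no firm difference between the cores, but with only two pairs, and both steps within the scatter, they do not show that the change carries over unchanged either. The compounds shown leave open what a longer chain or a chain ending in an amine would give in this place.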